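A few compounds are considered here, and "the series" means these few. Any claim that something is new, unique, unknown or untested is made for them only; others in the source may bear on it.

For the measured compounds named here, compound 2 `O=c1n(CCCCCCN2CCN(c3cccc4cccnc34)CC2)nc2ccccn12` carries quinolin-8-yl on the ring amine nitrogen; in an assay on HEK293 cells for displacement of a labelled ligand from 5-hydroxytryptamine receptor 7 (Homo sapiens), read by radioligand binding (a higher number here means a weaker inhibitor, a lower number a stronger inhibitor), compound 2 gives 655 nM, the highest of the two numbers so far. Going by the values given here, compound 1 `O=c1n(CCCCCCN2CCN(c3cccc(Cl)c3Cl)CC2)nc2ccccn12` gives 243 nM, and the only measured step, a 2.7-fold higher number from compound 1 to compound 2 (0.43 log units; beyond the scatter), is modest. Compound 3 `O=c1n(CCCCCCN2CCN(c3cccc4c3OCCO4)CC2)nc2ccccn12` is reached from compound 2 by 2,3-dihydro-1,4-benzodioxin-5-yl in place of quinolin-8-yl on an amine nitrogen in a ring. Among the compounds with values here, no measured step bears directly on this change; the one step at the same place is modest, so for compound 3 a step of a 1.6-fold lower number from compound 2 to compound 3 (0.21 log units; within the scatter) is expected, with direction uncertain. Compound 3 is estimated at 400 nM, range 150 nM to 1100 nM.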

Compound 3, inhibition constant: 271 nM
Estimate against measurement, compound 3: 1.5-fold (0.17 log units) above, and the stated range covers the measured number.
By their numbers in this assay, from the lowest: compounds 1 and 3 (each within the scatter of the next); then compound 2.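

At the ring amine nitrogen, 2,3-dihydro-1,4-benzodioxin-5-yl in place of quinolin-8-yl gives a 2.4-fold lower number from compound 2 to compound 3 (0.38 log units; beyond the scatter), so this position responds to a change between these two groups of equal heavy-atom count. Against 2,3-dichlorophenyl, the same group gives a 1.1-fold higher number from compound 1 to compound 3 (0.05 log units; within the scatter), which leaves compound 1 and compound 3 level in this assay, with only compound 2 apart from them. No available data explain these differences. As far as these compounds go, whether 2-methoxyphenyl on the same nitrogen would stand level with compound 1 and compound 3 remains open. From the compounds shown here alone, the effect of a shorter chain in place of the present one also remains open.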